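Swapping dimethylamino for methylpiperazinyl on the shared core

A few compounds are considered here, and "the series" means these few. Any claim that something is new, unique, unknown or untested is made for them only; others in the source may bear on it.

Compound 3 `CN(C)c1nc(NCc2ccc(C(=O)Nc3ccc(F)cc3)cc2)c2ccccc2n1` gives the second highest of three numbers in a functional assay on SW480 cells (Homo sapiens) for inhibition, read by luminescence and resazurin assay, with a stated time of 3 days (on this read-out higher numbers stand for weaker inhibition and lower numbers for stronger inhibition), namely 2600 nM. Compound 1 `CNc1nc(NCc2ccc(C(=O)Nc3ccc(F)cc3)cc2)c2ccccc2n1` gives 4100 nM, and compound 2 `CCCCNc1nc(NCc2ccc(C(=O)Nc3ccc(F)cc3)cc2)c2ccccc2n1` gives 1000 nM. Compound 4 `CC1CN(c2nc(NCc3ccc(C(=O)Nc4ccc(F)cc4)cc3)c3ccccc3n2)CCN1` carries 3-methylpiperazin-1-yl in place of dimethylamino on an aromatic carbon. Among the compounds with values here, two measured steps bear on changes at this same aromatic carbon: a 4.1-fold lower number from compound 1 to compound 2 (0.61 log units; beyond the scatter), and a 2.6-fold higher number from compound 2 to compound 3 (0.41 log units; beyond the scatter), while a 1.6-fold lower number from compound 1 to compound 3 (0.20 log units; within the scatter). A larger group at this carbon has so far gone with a lower number, compound 2 being the only such case. A modest lowering is therefore expected for compound 4, a 1.7-fold lower number from compound 3 to compound 4 (0.24 log units; within the scatter). The estimate for compound 4 is 1500 nM, within a range from 500 nM to 4500 nM.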

Compound 4, half-maximal inhibitory concentration: 3200 nM
The estimate for compound 4 lay 2.1-fold (0.33 log units) below the measured number; measured number inside the range.
By their numbers in this assay, from the lowest: compound 2; then compounds 3, 4 and 1 (each within the scatter of the next).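

In this assay, the 3-methylpiperazin-1-yl ring leaves the number within the scatter of the two smaller amino groups, with a 1.2-fold higher number from compound 3 to compound 4 (0.09 log units; within the scatter) and a 1.3-fold lower number from compound 1 to compound 4 (0.11 log units; within the scatter), while butylamino stays apart, with a 3.2-fold higher number from compound 2 to compound 4 (0.51 log units; beyond the scatter). Within the data shown here, a larger group at this aromatic carbon therefore does not by itself go with a lower number, and compound 2 remains the only compound with a clearly lower one. Nothing measured here accounts for this difference.

From the compounds shown here alone, whether the lower number of compound 2 follows from its open chain stays open. A hexylamino chain or a morpholin-4-yl ring at this carbon would bear on that.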